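Swapping pyrrolidin-1-yl for piperidin-1-yl on a shared core

The source may report more compounds than this note shows. Statements on the series, on what has been measured and on what is new or still open speak of the compounds shown alone.

Compound 1 `CCN(CC)Cc1ccc2c(c1O)-c1ccc(cc1O)CCc1ccc(O)c(c1)Oc1ccc(cc1)CC2`: 7860 nM
Compound 2 `Oc1ccc2cc1Oc1ccc(cc1)CCc1ccc(CN3CCCC3)c(O)c1-c1ccc(cc1O)CC2`: 4820 nM

Both compounds were tested in a functional assay on K562 cells (Homo sapiens) for antiproliferative activity, read by MTT assay, with a stated time of 48 h; on this read-out higher numbers stand for weaker inhibition and lower numbers for stronger inhibition. Among the measured compounds shown here, compound 2 cannot be separated from compound 1, the only other compound measured so far. For the measured compounds named here, the one comparison available is a 1.6-fold lower number from compound 1 to compound 2 (0.21 log units; within the scatter). In that step, pyrrolidin-1-yl took the place of diethylamino on a saturated chain carbon bound to an aromatic carbon.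

Compound 3 `Oc1ccc2cc1Oc1ccc(cc1)CCc1ccc(CN3CCCCC3)c(O)c1-c1ccc(cc1O)CC2` keeps the shared core and alters that same group: piperidin-1-yl in place of pyrrolidin-1-yl on a saturated chain carbon bound to an aromatic carbon. In words, piperidin-1-yl stands in place of pyrrolidin-1-yl.

Going by the values given here, the single measured step bears directly on this change, since it was made at the same place and also exchanged one nitrogen-linked group for another. It stayed within the scatter, so a second exchange there gives no reason to predict a real shift in either direction. Among the compounds with values here, this is thin evidence, as no measured compound yet carries piperidin-1-yl. In this assay, the expected change is therefore none beyond the scatter, with an estimated 1.0-fold higher number from compound 2 to compound 3 (0.02 log units; within the scatter). For compound 3 the estimated value is 5000 nM, with an expected range of 2400 nM to 10000 nM.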

Compound 3, half-maximal inhibitory concentration: 5880 nM
Compound 3: the middle estimate sits 1.2-fold (0.07 log units) below what was measured; low and high end bracket the measured number.
By their numbers in this assay, from the lowest: compounds 2, 3 and 1 (each within the scatter of the next).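

In this assay, enlarging the ring on the saturated chain carbon bound to an aromatic carbon from five-membered to six-membered leaves the result within the usual scatter (with a 1.2-fold higher number from compound 2 to compound 3 (0.09 log units; within the scatter)). The second comparison now available sets the open-chain diethylamino group against the piperidin-1-yl ring and also stays within the scatter (with a 1.3-fold lower number from compound 1 to compound 3 (0.13 log units; within the scatter)), so the ring in compound 3 cannot be told apart from the open chain in compound 1. Across compounds 1, 2 and 3, then, these three nitrogen-linked groups cannot be separated from one another in this test, though the data offer no measured explanation for that sameness.

From the compounds shown here alone, all three groups join the chain carbon through a nitrogen that carries only carbon atoms, so the effect of a morpholin-4-yl ring, which adds an oxygen atom, or of a primary amine or a carboxylic acid at this place remains open. Also open is whether any change at this place can move the number beyond the scatter, since every step shown here stays within it.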